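The compounds below may be only part of what the source reports. "The series", "measured", "known", "first", "only" and "open" are said of these compounds alone.

Measured so far in a functional assay on K562 cells (Homo sapiens) for cytotoxicity, read by MTT assay, with a stated time of 24 h; on this read-out higher numbers stand for weaker inhibition and lower numbers for stronger inhibition:
- compound 1 `CN1C/C(=C\c2cccc([N+](=O)[O-])c2)C(=O)/C(=C/c2ccccc2F)C1`: 3890 nM
- compound 2 `COc1cc(/C=C2\CN(C)C/C(=C\c3ccc(Cl)cc3)C2=O)cc(OC)c1`: 13300 nM

Compound 1 holds the lower of the two numbers, so it is the stronger inhibitor of the pair. Compound 1 at 3890 nM stands clear of compound 2 at 13300 nM, and that gap lies beyond the usual scatter. The two compounds differ in more than one place, so their gap cannot be tied to any single change.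

Next in line is compound 3 `CN1C/C(=C\c2cccc(Br)c2)C(=O)/C(=C/c2cccc([N+](=O)[O-])c2)C1`, which has 3-bromophenyl in place of 2-fluorophenyl on a double-bonded chain carbon bound to a double-bonded ring carbon. Among the measured compounds shown here, no measured pair shows this exchange, so the expectation rests on compound 1 at 3890 nM, with compound 2 at 13300 nM as the only guide to spread. In this assay the expected step is a 1.0-fold higher number from compound 1 to compound 3 (0.01 log units; within the scatter), which means no change beyond the scatter in either direction. For compound 3 the estimated value is 4000 nM, with an expected range of 1500 nM to 12000 nM.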

Compound 3, half-maximal inhibitory concentration: 12200 nM
Compound 3: the middle estimate sits 3.1-fold (0.48 log units) below what was measured; the measured number lies above the stated range.
By their numbers in this assay, from the lowest: compound 1; then compounds 3 and 2 (each within the scatter of the next).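

In this assay, the change to 3-bromophenyl from 2-fluorophenyl on a double-bonded chain carbon bound to a double-bonded ring carbon gives a 3.1-fold higher number from compound 1 to compound 3 (0.50 log units; beyond the scatter) with the rest of the molecule held constant. Among the compounds shown here, this is the first single-place comparison, and it shows that activity at this position depends on which halogenated phenyl group is present, even though the two groups match in heavy-atom count and hydrogen-bond donor and acceptor counts. No measurement shown gives a reason for this step.

The step changes both the halogen and its place on the phenyl ring, so the contribution of each stays unresolved; 2-bromophenyl and 3-fluorophenyl at this position would separate the two. Also open, on these data alone, is how an unsubstituted phenyl, a 4-methoxyphenyl or a pyridyl ring would compare here, and whether this step would hold with a different group in place of the 3-nitrophenyl kept in compound 1 and compound 3.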